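Hydroxycyclohexyl to cyclobutyl on the amine of compound 2

The source may hold more compounds than are shown below. What is called first, only, known or untested is meant among the compounds shown, and "the series" means these compounds.

Within the data shown here, compound 2 `OC1CCC(Nc2nc(-c3ccccc3)nc3c2nnn3Cc2ccccc2Cl)CC1` is, in an assay on isolated protein for binding affinity to adenosine receptor A1 (Bos taurus) (a higher number here means a weaker inhibitor, a lower number a stronger inhibitor), the higher of the two numbers so far: compound 2 gives 3100000 nM, while compound 1 `OC1CCC(Nc2nc(-c3ccccc3)nc3c2nnn3Cc2ccccc2)CC1` gives 2700000 nM. The gap between them, a 1.1-fold higher number from compound 1 to compound 2 (0.06 log units; within the scatter), is within the scatter, so the two cannot be ordered.

Compound 3 `Clc1ccccc1Cn1nnc2c(NC3CCC3)nc(-c3ccccc3)nc21` is not yet measured. It differs from compound 2 by cyclobutyl in place of 4-hydroxycyclohexyl on a nitrogen on an aromatic ring. Among the measured compounds shown here, none of the measured steps touches this position: the only step in hand, from compound 1 to compound 2, concerns a chloro in place of hydrogen on an aromatic carbon and lies within the scatter, so it carries no information on the amine substituent. The expectation therefore rests on the shared core alone, whose two representatives sit close together at very weak binding.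

For the measured compounds named here, with no bearing step, a change beyond the scatter is possible in either direction but cannot be argued from these data. For compound 3 the expected value in this assay is 1500000 nM, spanning 300000 nM to 8000000 nM. The expected step is a 2.1-fold lower number from compound 2 to compound 3 (0.32 log units; beyond the scatter), with low confidence.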

Compound 3, inhibition constant: 24000000 nM
For compound 3 the middle estimate is 16-fold (1.20 log units) below the measured one; measured number outside the range, above it.
By their numbers in this assay, from the lowest: compounds 1 and 2 (each within the scatter of the next); then compound 3.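

In this assay, among these compounds, the amine substituent is the first place where a single change moves the number beyond the scatter: cyclobutyl in place of 4-hydroxycyclohexyl gives a 7.7-fold higher number from compound 2 to compound 3 (0.89 log units; beyond the scatter), whereas the chloro step on the aromatic carbon stayed within it. This position therefore affects binding even in a series this weak, and the values of compound 1 and compound 2 do not mark the weak end of what the shared core can give. The step changes several things at once, with the ring going from six-membered to four-membered and the hydroxyl, with its hydrogen-bond donor and acceptor, leaving, and no supporting measurement points to any one of these as the cause.

Ring size and the hydroxyl therefore remain unseparated here; a plain cyclohexyl on the same nitrogen would divide the step into its two parts, and a cyclopentyl would add an intermediate ring size. On these data alone, whether any group at this position, such as a cyclohexyl carrying an amine or a carboxylic acid, brings the number below that of compound 2 also stays open.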